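The source may hold more compounds than are shown below. What is called first, only, known or untested is meant among the compounds shown, and "the series" means these compounds.

Compound 1 `N#Cc1c(-c2ccccc2O)cc(-c2ccsc2)[nH]c1=N`: "not determined" (no result reported)
Compound 2 `CCOc1ccccc1-c1cc(-c2ccsc2)[nH]c(=N)c1C#N`: 6000 nM

These two compounds were examined in a functional assay on HT-29 cells (Homo sapiens) for cytotoxicity, with a stated time of 72 h; a higher number here means a weaker inhibitor, a lower number a stronger inhibitor. For the measured compounds named here, compound 2, at 6000 nM, holds the only number so far, so it cannot yet be ranked against anything. Compound 1 has no result in this assay and offers no comparison.

The next compound to be measured is compound 3 `COc1ccccc1-c1cc(-c2ccsc2)[nH]c(=N)c1C#N`, which departs from compound 2 in a single place: hydrogen in place of methyl on a saturated chain carbon bound to an oxygen on an aromatic ring. In words, hydrogen stands in place of methyl on a saturated chain carbon bound to an oxygen on an aromatic ring, turning ethoxy into methoxy. The rest of the structure is unchanged.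

Going by the values given here, no measured pair shows what such a change does, so the expectation rests on the value of compound 2, 6000 nM, and on how small the change is. The expected step of a 1.2-fold lower number from compound 2 to compound 3 (0.08 log units; within the scatter) is no larger than the usual scatter, with no firm direction. The estimate for compound 3 is 5000 nM, with an expected range from 1800 nM to 14000 nM.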

Compound 3, half-maximal inhibitory concentration: 35000 nM
The estimate for compound 3 lay 7.0-fold (0.85 log units) below the measured number; the measured number lies above the stated range.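

In this assay, turning ethoxy into methoxy gives a 5.8-fold higher number from compound 2 to compound 3 (0.77 log units; beyond the scatter), so the loss of a single methyl from the saturated chain carbon bound to an oxygen on an aromatic ring is enough to move the number beyond the usual scatter. This pair gives the series its first direction at this place: the ethoxy of compound 2 goes with the stronger result and the methoxy of compound 3 with the weaker one, although a single pair establishes no trend. No measurement of any property bears on this step, so its origin remains unexplained.

The compounds shown leave open whether the number would fall further with a longer chain such as propoxy or butoxy, or whether a branched isopropoxy or a chain ending in an amine would behave like ethoxy. They also leave open whether a step of this size would recur if the shared core were changed elsewhere, since this one pair tests the change in a single setting.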